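Compound 3: benzamido at the former allyloxy position

The source may report more compounds than this note shows. Statements on the series, on what has been measured and on what is new or still open speak of the compounds shown alone.

Compound 2 `COc1ccc(C2=C(c3cc(OC)c(OC)c(OC)c3)C(=O)C(O)C2)cc1` is the reference point of the pair. In an ADME assay on L132 cells (Homo sapiens) for cytotoxicity, read by MTT assay, with a stated time of 72 h (on this read-out higher numbers stand for weaker inhibition and lower numbers for stronger inhibition), compound 2 gives < 1 ug/mL, which is a limit of the assay and not a number. Compound 1 `C=CCOc1cc(C2=C(c3cc(OC)c(OC)c(OC)c3)C(=O)C(O)C2)ccc1OC` carries allyloxy on the aromatic carbon that bears hydrogen in compound 2. In this assay compound 1 gives > 100 ug/mL, likewise a limit. The step of an at least 100-fold lower number from compound 1 to compound 2 (2.00 log units; beyond the scatter) is therefore only a lower bound on its size, because the limit of < 1 ug/mL in this assay, at which 1 of the 2 values shown sits, and the limit of > 100 ug/mL in this assay, at which 1 of the 2 values shown sits, cap both ends; all that is known is that it is large. Compound 2 thus sits at the low end of the two values shown.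

Compound 3 `COc1ccc(C2=C(c3cc(OC)c(OC)c(OC)c3)C(=O)C(O)C2)cc1NC(=O)c1ccccc1` differs from compound 2 by benzamido in place of hydrogen on an aromatic carbon. The only measured step touching this carbon is an at least 100-fold lower number from compound 1 to compound 2 (2.00 log units; beyond the scatter): removing allyloxy from it lowered the number by the large amount shown. Adding benzamido there is taken to run the other way, so compound 3 is expected to move upward in this assay, by an at least 20-fold higher number from compound 2 to compound 3 (1.30 log units; beyond the scatter). The estimate for compound 3 is 20 ug/mL, with a range from 2 ug/mL to 100 ug/mL.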

Compound 3, half-maximal inhibitory concentration: > 100 ug/mL
Compound 3: a limit, no number; the forecaster's own chance of this, stated with the estimate: 30%; middle value at least 5.0-fold (0.69 log units) from the limit.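

With compound 2 as the reference, the step of an at least 100-fold higher number from compound 2 to compound 3 (2.00 log units; beyond the scatter) in this assay shows that the rise in the number at this aromatic carbon, ortho to a methoxy group, is not confined to allyloxy, since benzamido in place of hydrogen gives a step of the same printed bound. On these data alone, compound 3 gives > 100 ug/mL, which is a limit of the assay and not a number, so the true size of this step remains unknown. The step between compound 1 and compound 3 cannot be read, and allyloxy and benzamido cannot be ranked against each other at this carbon: the limit of > 100 ug/mL in this assay, at which 2 of the 3 values shown sit.

The compounds shown leave open whether only hydrogen at this carbon keeps the number low, or whether a small group such as an amine or a hydroxyl would stay close to compound 2. They also leave open how the number responds across intermediate groups, such as an acetamide or a short alkyl ether, which could show where between the two limits the change sets in.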